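Cyano to propoxy in the sulfoxide vinyl series

A few compounds are considered here, and "the series" means these few. Any claim that something is new, unique, unknown or untested is made for them only; others in the source may bear on it.

Values so far in a functional assay on DLD-1 cells (Homo sapiens) for cytotoxicity, with a stated time of 48 h (a higher number here means a weaker inhibitor, a lower number a stronger inhibitor), as follows
- compound 1 `CC(C)COc1ccc2oc(/C=C/[S+](C)[O-])cc(=O)c2c1` gives 5000 nM
- compound 2 `CCCCOc1ccc2oc(/C=C/[S+](C)[O-])cc(=O)c2c1` gives 4800 nM
- compound 3 `C[S+]([O-])/C=C/c1cc(=O)c2cc(C#N)ccc2o1` gives > 10000 nM as a limit

Compound 3 stands at > 10000 nM in this assay and this is a limit of the assay, not a number. The next case is compound 4 `CCCOc1ccc2oc(/C=C/[S+](C)[O-])cc(=O)c2c1` with propoxy in place of cyano on an aromatic carbon of the shared core: propoxy in place of cyano on an aromatic carbon is the counted change.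

For the measured compounds named here, two measured steps bear on this, both running in the reverse direction. Cyano in place of butoxy gives an at least 2.0-fold higher number from compound 2 to compound 3 (0.31 log units; beyond the scatter) and cyano in place of isobutoxy gives an at least 2.0-fold higher number from compound 1 to compound 3 (0.30 log units; that floor lies within the scatter) on the same carbon. Both are floors set by the limit of compound 3. Among the chains themselves, propyl in place of isopropyl gives a 1.0-fold lower number from compound 1 to compound 2 (0.02 log units; within the scatter) as the only measured chain step. Compound 4 is therefore expected to sit close to compound 1 at 5000 nM and compound 2 at 4800 nM in this assay once its chain is in place. The expected step is an at least 2.0-fold lower number from compound 3 to compound 4 (0.30 log units; that floor lies within the scatter) toward a lower number. The estimate for compound 4 is 5000 nM with an expected range from 2500 nM to 10000 nM for now.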

Compound 4, half-maximal inhibitory concentration: 6200 nM
Estimate against measurement, compound 4: 1.2-fold (0.09 log units) below; the measured number falls inside the stated range.
By their numbers in this assay, from the lowest: compounds 2, 1 and 4 (each within the scatter of the next). At a limit, above all of these: compound 3.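

In this assay, propoxy on this aromatic carbon gives a measured number where cyano does not, and the change reads as an at least 1.6-fold lower number from compound 3 to compound 4 (0.20 log units; that floor lies within the scatter), so this floor alone does not set the two groups apart beyond the scatter. Compound 3 stands at a limit of the assay, not a number: the limit of > 10000 nM in this assay, at which 1 of the 4 values shown sits.

Among the ether chains at this position, the propoxy chain adds a third member with no step beyond the scatter, a 1.3-fold higher number from compound 2 to compound 4 (0.11 log units; within the scatter) and a 1.2-fold higher number from compound 1 to compound 4 (0.09 log units; within the scatter), so compound 1, compound 2 and compound 4 cannot be told apart in this assay, whether the chain is propoxy, butoxy or isobutoxy.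

Going by these compounds, how large the true gap between cyano and these ethers is remains open, and so does whether any group on this carbon can bring the number beyond the scatter of these three chains. A methoxy, a longer chain such as octyloxy, an amine or a carboxylic acid at this position would be the next points to read against compound 4 in this assay.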